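The compounds below may be only part of what the source reports. "The series", "measured", "known", "first", "only" and "open" are said of these compounds alone.

Measured compounds and their values in this assay:

Compound 1 `CC(=O)N[C@@H]1CCN(c2cc(C)nn3c(-c4ccc5cc[nH]c5c4)c(C)nc23)C1`: > 95%
Compound 2 `COc1ccc(-c2c(C)nc3c(N4CC[C@@H](NC(=O)COc5ccccc5)C4)cc(C)nn23)cc1OC`: > 95%
Compound 3 `COc1ccc(-c2c(C)nc3c(N4CC[C@H](O)C4)cc(C)nn23)cc1OC`: > 95%

All three were run in an ADME assay on microsomes from liver (Mus musculus) for metabolic stability, read by LC-MS, with NADPH named in the record, with a stated time of 60 min, tested at 1 uM, in the absence of a further agent; a higher number here means that more of the compound is left, a lower number that less of the compound is left. Compound 2 gives > 95% in this assay, and that figure is a limit of the assay rather than a number. The same holds for the others: the limit of > 95% in this assay, at which 3 of the 3 values shown sit. Compound 2 therefore stands with the other two at the top of what this assay reports, and none of the three can be placed above or below another.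

The unmeasured compound 4 `COc1ccc(-c2c(C)nc3c(N4CC[C@@H](n5cc(-c6ccccc6)nn5)C4)cc(C)nn23)cc1OC` differs from compound 2 in one place: 4-phenyl-1H-1,2,3-triazol-1-yl in place of ((phenoxymethyl)carbonyl)amino on a saturated ring carbon. Going by the values given here, no measured pair in this set shares that change, so the size of its step is unknown. Given that compound 2 sits at the limit with > 95%, the step of a number at least 5 percentage points lower from compound 2 to compound 4 (that floor lies within the scatter) is expected to lie within the scatter, with the readout staying high. Compound 4 is thus expected to give 90%, within the range 72% to 99%.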

Compound 4, percent of the compound remaining: "unstable" (no number reported)
Nothing numeric was reported for compound 4; there is nothing to compare the estimate with.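

No step can be read between compound 2 and compound 4. Compound 4 is recorded only as "unstable" (no number reported), without a number. Compound 2 has only a limit. The compounds shown leave open how much of compound 4 remains, and whether the 4-phenyl-1H-1,2,3-triazol-1-yl group accounts for that record.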